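From an Acetyl Group to a Pentenyl Chain

This account rests on a few compounds, and the source may have more. Where it says the series, first, only, none or still open, it means among the compounds named here.

Of the compounds shown here, two sharing one core have been measured in a functional assay on the whole organism (Abdomen, strain Swiss) for inhibition, with Mus musculus as the target, with stated times of 30 min, 10 min and 5 min, at a dose of 10 mg/kg by the oral route; a higher number here means a stronger effect of the compound at the dose given, a lower number a weaker effect. Compound 1, `CC(=O)c1c(C)nn(CCCN2CCN(c3ccc(C)cc3)CC2)c(=O)c1N`, gives 19%, the highest of the two numbers. Compound 2, `CCC(=O)c1c(C)nn(CCCN2CCN(c3ccc(C)cc3)CC2)c(=O)c1N`, gives 9%. Within the data shown here, the only step that separates these two, methyl in place of hydrogen on a saturated chain carbon bound to a carbonyl carbon, is a number 10 percentage points lower from compound 1 to compound 2 (within the scatter), so on the present numbers the two compounds cannot be told apart.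

Compound 3, `CCC/C=C/c1c(C)nn(CCCN2CCN(c3ccc(C)cc3)CC2)c(=O)c1N`, has not yet been measured. It differs from compound 1 in one place: pent-1-en-1-yl in place of acetyl on an aromatic carbon. The acetyl group, with its one hydrogen-bond acceptor, leaves, and a pent-1-en-1-yl chain with no acceptor enters.

Among the measured compounds shown here, no measured step touches this kind of exchange. For the measured compounds named here, the single step in hand, from compound 1 to compound 2, stayed within the scatter and changed only the chain on the carbonyl side, not the group itself. Nothing therefore points to a step beyond the scatter, and the expected step is a number 7 percentage points lower from compound 1 to compound 3 (within the scatter). The estimate for compound 3 in this assay is 12%, with a range from 0% to 30%.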

Compound 3, a percentage reported as inhibition, in the whole organism at one dose (the size of the read-out at that dose, not a potency): 0%
The estimate for compound 3 lay 12 percentage points above the measured number; measured number inside the range.
By their numbers in this assay, from the lowest: compounds 3, 2 and 1 (each within the scatter of the next, the first and the last beyond it).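

In this assay, among these compounds, replacing acetyl with pent-1-en-1-yl on the aromatic carbon opposite the ring nitrogen gives the first step in this small set that clears the scatter: a number 19 percentage points lower from compound 1 to compound 3 (beyond the scatter). Measured from the propanoyl group of compound 2, the same kind of exchange gives a number 9 percentage points lower from compound 2 to compound 3 (within the scatter), so compound 2 cannot be told apart from compound 3 any more than from compound 1, and only the two ends of the series, compound 1 and compound 3, are separated, by a modest step. This shows that the position can respond to a change of the whole group, where lengthening the chain on the carbonyl side did not show a clear response, but nothing available on these compounds offers an explanation for the step.

The exchange alters two things at once, removing the carbonyl with its hydrogen-bond acceptor and bringing in a larger all-carbon chain, so the compounds shown cannot say which of the two matters. A pentanoyl group, which keeps the carbonyl on a longer chain, and a short ethyl group, which has neither carbonyl nor long chain, would begin to pull those two changes apart.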